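The source may report more compounds than this note shows. Statements on the series, on what has been measured and on what is new or still open speak of the compounds shown alone.

Compound 1 `CCOC(=O)/C=C/c1ccc(OC(=O)c2nc(C)c(C)nc2C)c(O)c1`: 207%
Compound 2 `CCOC(=O)/C=C/c1cc(OC)c(O)c(OC)c1`: 24.9%
Compound 3 `Cc1nc(C)c(C(=O)Oc2cccc(/C=C/C(=O)O)c2)nc1C`: 64.3%

In a functional assay on EA.hy 926 cells (Homo sapiens) for cytotoxicity, read by MTT assay, with stated times of 24 h and 12 h, tested at 25 uM (a higher number here means a stronger effect of the compound at the concentration tested, a lower number a weaker effect), compound 1 gives the highest of the three numbers; compound 3 lies below it by a margin beyond the usual scatter, and compound 2 lies lower still, again beyond the scatter. Compound 4 `CCOC(=O)/C=C/c1ccc(OC(=O)c2nc(C)c(C)nc2C)cc1` has not been measured. It differs from compound 1 in one place: hydrogen in place of hydroxy on an aromatic carbon. Within the data shown here, no pair of measured compounds shows exactly this change, so its effect is not known directly; compounds 2 and 3 both lack a free hydroxy on the ring and both give far smaller numbers than compound 1, but each also differs from compound 1 elsewhere. A decrease in this assay beyond the scatter is therefore expected, of the size a number 107 percentage points lower from compound 1 to compound 4 (beyond the scatter). Compound 4 is estimated at 100%, within a range from 35% to 190%.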

Compound 4, a percentage reported as activity, at one concentration (the size of the read-out at that concentration, not a potency): 58.8%
Beside the measured number, compound 4's estimate is 41.2 percentage points above it; the measured number falls inside the stated range.
By their numbers in this assay, from the lowest: compound 2; then compounds 4 and 3 (each within the scatter of the next); then compound 1.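

Hydrogen in place of hydroxy on this aromatic carbon, ortho to a large group, gives [ a number 148.2 percentage points lower from compound 1 to compound 4 (beyond the scatter) ] in this assay. Among these compounds, this is the first comparison to isolate the hydroxy, which compounds 2 and 3 could not do, and it shows that this single change is enough to produce a large loss from the high number of compound 1. Nothing shown accounts for the size of this step. On these data alone, it remains open whether an amine or a fluorine on this carbon would retain the number of compound 1 or fall towards that of compound 4.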